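Enamine ketones on a shared core: toward an indolyl variant

The compounds below may be only part of what the source reports. "The series", "measured", "known", "first", "only" and "open" are said of these compounds alone.

Measured compounds:
Compound 1 `COc1ccc(N/C=C\C(=O)c2nc(-c3ccc(F)cc3)n3ccccc23)cc1` — in a functional assay on BT-474 cells (Homo sapiens) for cytotoxicity, read by MTT assay, with a stated time of 48 h (a lower number here means a stronger inhibitor, a higher number a weaker inhibitor), compound 1 gives 15700 nM
Compound 2 `COc1ccc(N/C=C\C(=O)c2nc(-c3ccccc3)n3ccccc23)cc1` — in this assay compound 2 gives 12800 nM

Compound 1 stands at the higher of the two numbers, but the gap to compound 2 is small: the step of a 1.2-fold lower number from compound 1 to compound 2 (0.09 log units; within the scatter) lies within the scatter, so the two cannot be told apart on these data. That step replaces a fluoro with hydrogen on an aromatic carbon and says nothing about the aryl group on the amine nitrogen.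

Compound 3 `Cc1cc2cc(N/C=C\C(=O)c3nc(-c4ccc(F)cc4)n4ccccc34)ccc2[nH]1` arises from compound 1 by 2-methyl-1H-indol-5-yl in place of 4-methoxyphenyl on an amine nitrogen. Going by the values given here, no measured pair touches that part of the molecule, so the one step in hand gives no guidance on its direction or size. With nothing to build on beyond the two values near one another, a step of moderate size in either direction is the most that can be anticipated, and a wide range is warranted. Compound 3 is therefore expected to give about 10000 nM in this assay, between 2500 nM and 40000 nM, which corresponds to an expected step of a 1.6-fold lower number from compound 1 to compound 3 (0.20 log units; within the scatter).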

Compound 3, half-maximal inhibitory concentration: > 30000 nM
Compound 3 ended at the assay's limit (the forecaster's own chance of this, stated with the estimate: 10%); at least 3.0-fold (0.47 log units) between middle value and limit.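

Compound 3 gives > 30000 nM in this assay, and this entry is a limit of the assay, not a number. Placing 2-methyl-1H-indol-5-yl in place of 4-methoxyphenyl on the amine nitrogen, the first change at this position among the compounds shown, gives an at least 1.9-fold higher number from compound 1 to compound 3 (0.28 log units; that floor lies within the scatter), so the change brought no lower number, while the real size of the step stays unknown and only its floor can be read. The step from fluoro to hydrogen had said nothing about this position, and the new reading is still bounded by a single entry at the top of the range: the limit of > 30000 nM in this assay, at which 1 of the 3 values shown sits.

The compounds shown leave open whether the methyl on the indolyl group matters, and whether 1H-indol-5-yl, 4-hydroxyphenyl or 4-aminophenyl on the amine nitrogen would read like 4-methoxyphenyl or like 2-methyl-1H-indol-5-yl. As far as these compounds go, it also remains open whether the same exchange of groups would give a similar result on the core of compound 2, which carries hydrogen in place of fluoro.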